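A few compounds are considered here, and "the series" means these few. Any claim that something is new, unique, unknown or untested is made for them only; others in the source may bear on it.

Measured compounds in an ADME assay on HepG2 cells (Homo sapiens) for cytotoxicity, read by luminescence, CellTiter-Glo and ATP content, with a stated time of 72 h; a lower number here means that less compound is needed, a higher number that more compound is needed for the effect:

compound 1, `CC(C)Cc1ccc2c(NCCCNCc3ccco3)ccnc2c1`: 16000 nM
compound 2, `COc1ccc(F)cc1CNCCCNc1ccnc2cc(CC(C)C)ccc12`: 2900 nM
compound 3, `COc1ccc(-c2ccc3c(NCCCNCc4ccco4)ccnc3c2)cc1`: 6000 nM

Compound 2 has the lowest number of the three in this assay; compound 3 sits nearest, and compound 1 furthest, both beyond the scatter. Two steps are known. From compound 1 to compound 2, a 5.5-fold lower number from compound 1 to compound 2 (0.74 log units; beyond the scatter), with the change on the saturated chain carbon bound to the amine nitrogen. From compound 1 to compound 3, a 2.7-fold lower number from compound 1 to compound 3 (0.43 log units; beyond the scatter), with the change on the aromatic carbon of the shared core.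

Compound 4, `CCC(CC)c1ccc2c(NCCCNCc3cc(F)ccc3OC)ccnc2c1`, is not yet measured. It differs from compound 2 in one place: pentan-3-yl in place of isobutyl on an aromatic carbon. Among the compounds with values here, the only step that touches this position is the one from compound 1 to compound 3, where an aryl group replaced isobutyl and the number fell modestly. Here the replacement is another branched alkyl group, pentan-3-yl for isobutyl, so that step is only a loose guide; no alkyl-to-alkyl exchange at this carbon has been measured. The expectation is therefore a small step in this assay, at most near the scatter and in no firm direction.

Compound 4 is estimated at 2600 nM, range 1200 nM to 5800 nM, which means an expected step of a 1.1-fold lower number from compound 2 to compound 4 (0.05 log units; within the scatter).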

Compound 4, half-maximal effective concentration: 7860 nM
For compound 4 the middle estimate is 3.0-fold (0.48 log units) below the measured one; the measured number lies above the stated range.
By their numbers in this assay, from the lowest: compound 2; then compounds 3 and 4 (each within the scatter of the next); then compound 1.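

In this assay, pentan-3-yl in place of isobutyl on the aromatic carbon gives a 2.7-fold higher number from compound 2 to compound 4 (0.43 log units; beyond the scatter) and shows that this position responds to an exchange of one branched alkyl group for another, so more compound is needed for the effect with the new group. Within the data shown here, the only earlier step at this carbon, 4-methoxyphenyl in place of isobutyl, gives a 2.7-fold lower number from compound 1 to compound 3 (0.43 log units; beyond the scatter) and runs the other way, although it was read with the furan-2-yl side chain, whereas the new step was read with the 5-fluoro-2-methoxyphenyl side chain. Thus isobutyl is the lowest of the alkyl groups seen here with that side chain, but the two compounds offer only one alkyl comparison, and no measurement in hand accounts for the rise.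

Open, going by these compounds, is whether pentan-3-yl would shift the number in the same direction with the furan-2-yl side chain, and whether 4-methoxyphenyl would lower it with the 5-fluoro-2-methoxyphenyl side chain. Also open, on these data alone, is how a straight pentyl chain, a cyclopropyl ring or a morpholine would behave on this aromatic carbon.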